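Swapping an aryl group for a tetrazole in a ketone series

The source may report more compounds than this note shows. Statements on the series, on what has been measured and on what is new or still open speak of the compounds shown alone.

Of the compounds shown here, three have been measured in an assay for inhibition of 17-beta-hydroxysteroid dehydrogenase type 2 (Homo sapiens), read by HPLC, with a stated time of 10 min, tested at 1 uM; a higher number here means more inhibition at the concentration tested (going by the name of the read-out), a lower number less inhibition. Compound 1, with structure `Oc1cc(Oc2cccc(-c3cccc(O)c3F)n2)ccc1F`, gives 100% in this assay. Compound 2, with structure `Cc1ccc2nc(C(=O)c3ccc(F)c(O)c3)ccc2c1`, gives 78%. Compound 3, with structure `Cc1cc(-c2ccc3ccc(C(=O)c4ccc(F)c(O)c4)nc3c2)ccc1O`, gives 80%. On these numbers compound 3 stands second highest of the three: its nearest neighbour is compound 2, whose value lies within the usual scatter of compound 3, and the furthest is compound 1, which lies beyond the scatter and higher.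

The next compound, compound 4, has structure `O=C(c1ccc(F)c(O)c1)c1ccc2ccc(-c3nnn[nH]3)cc2n1`. It differs from compound 3 in one place: 1H-tetrazol-5-yl in place of 4-hydroxy-3-methylphenyl on an aromatic carbon. Among the compounds with values here, no pair of measured compounds shows a change of this kind, so the direction of the step rests only on the values of compound 2 and compound 3, which sit within the scatter of each other despite their different groups at this place. A small step downward is expected, from compound 3 to compound 4, of a number 15 percentage points lower from compound 3 to compound 4 (beyond the scatter). Compound 4 is expected to give about 65%, within a range of 35% to 90%.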

Compound 4, a percentage reported as inhibition, at one concentration (the size of the read-out at that concentration, not a potency): 52%
For compound 4 the middle estimate is 13 percentage points above the measured one, and the stated range covers the measured number.
By their numbers in this assay, from the lowest: compound 4; then compounds 2 and 3 (each within the scatter of the next); then compound 1.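

At the aromatic carbon para to a fused ring, this assay now gives a first readable step: 1H-tetrazol-5-yl in place of 4-hydroxy-3-methylphenyl gives a number 28 percentage points lower from compound 3 to compound 4 (beyond the scatter) and shows that inhibition at this concentration depends on the group at this place. The drop is only partial, as compound 4 still gives 52% in this assay at the single concentration tested, a number that shows the size of the effect and not a potency. No measurement shown here bears on the reason for this drop.

One step cannot tell whether the lower number follows from the tetrazole entering or from the 4-hydroxy-3-methylphenyl leaving. Open too, on these data alone, is how a carboxylic acid or an unsubstituted phenyl at this same carbon would compare in this assay with these two groups.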